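Chloro for fluoro on the phenyl of compound 3

The source may report more compounds than this note shows. Statements on the series, on what has been measured and on what is new or still open speak of the compounds shown alone.

Compound 1 `O=c1oc2cccnc2n1CN1CCN(c2ccccc2)CC1` gives 5.9 mg/kg in a functional assay on the whole organism with Mus musculus as the target; a lower number here means that less compound is needed, a higher number that more compound is needed for the effect. Compound 2 `COc1ccccc1N1CCN(Cn2c(=O)oc3cccnc32)CC1` reaches only a limit in this assay, > 25 mg/kg, which is one of the assay's limits (the limit of > 25 mg/kg in this assay, at which 1 of the 3 values shown sits). Compound 3 `O=c1oc2cccnc2n1CN1CCN(c2ccc(F)cc2)CC1` gives 3.5 mg/kg in this assay. Of the two numbers shown, compound 3 stands nearest compound 1, and a 1.7-fold lower number from compound 1 to compound 3 (0.23 log units; within the scatter). The other steps are larger: an at least 4.2-fold higher number from compound 1 to compound 2 (0.62 log units; beyond the scatter), and an at least 7.1-fold lower number from compound 2 to compound 3 (0.85 log units; beyond the scatter).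

Compound 4 `O=c1oc2cccnc2n1CN1CCN(c2ccc(Cl)cc2)CC1` has not yet been measured in this assay. Its difference from compound 3 is chloro in place of fluoro on an aromatic carbon. For the measured compounds named here, the only measured step at this position is a 1.7-fold lower number from compound 1 to compound 3 (0.23 log units; within the scatter), which stayed within the scatter; no measured step exchanges fluoro for chloro. Going by the values given here, nothing among the measured steps therefore points to a shift beyond the scatter, and compound 4 is expected to sit close to compound 3 in this assay, with an estimated step of no change at the digits printed from compound 3 to compound 4 (within the scatter). For compound 4 the expected value in this assay is 3.5 mg/kg, in the estimated range from 1.5 mg/kg to 9 mg/kg.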

Compound 4, dose for half-maximal effect: 10.6 mg/kg
Compound 4: the middle estimate sits 3.0-fold (0.48 log units) below what was measured, outside the stated range (above it).
By their numbers in this assay, from the lowest: compounds 3, 1 and 4 (each within the scatter of the next, the first and the last beyond it). At a limit, above all of these: compound 2.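

Exchanging one halogen for another on the aromatic carbon para to a large group is not silent in this assay: the result shows a 3.0-fold higher number from compound 3 to compound 4 (0.48 log units; beyond the scatter) even though hydrogen to fluoro had stayed within the scatter. Chloro in place of hydrogen also stays within the scatter, with a 1.8-fold higher number from compound 1 to compound 4 (0.25 log units; within the scatter) as its step, so each halogen lies within the scatter of compound 1 while the two lie beyond it of each other. Compound 2 remains at a limit of the assay, so an at least 2.3-fold lower number from compound 2 to compound 4 (0.37 log units; beyond the scatter) is bounded on one side only: the limit of > 25 mg/kg in this assay, at which 1 of the 4 values shown sits.

On these data alone, it remains open whether bromo or trifluoromethyl at this place would track with fluoro or with chloro. Also open, as far as these compounds go, is whether a 4-methoxyphenyl group would stay at a limit, as the 2-methoxyphenyl group of compound 2 does.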